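A Fluoro Step Repeated on a Weaker Core

A few compounds are considered here, and "the series" means these few. Any claim that something is new, unique, unknown or untested is made for them only; others in the source may bear on it.

Three compounds have been measured in a functional assay on MCF7 cells (Homo sapiens) for cytotoxicity, read by MTT assay, with a stated time of 72 h; a lower number here means a stronger inhibitor, a higher number a weaker inhibitor:

compound 1 `O=C(Nc1ccc(Oc2ccnc3[nH]ccc23)cc1)c1nn(-c2ccccc2)ccc1=O` gives 15600 nM
compound 2 `O=C(Nc1ccc(Oc2ccnc3[nH]ccc23)c(F)c1)c1nn(-c2ccccc2)ccc1=O` gives 34900 nM
compound 3 `Cn1ccc2c(Oc3ccc(NC(=O)c4nn(-c5ccc(Cl)cc5)ccc4=O)cc3)ccnc21` gives only a limit, > 60000 nM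

Compound 2 differs from compound 1 by fluoro in place of hydrogen on an aromatic carbon, and the step was a 2.2-fold higher number from compound 1 to compound 2 (0.35 log units; beyond the scatter). Compound 3 sits at the limit of > 60000 nM in this assay, at which 1 of the 3 values shown sits, so no number is known for it. How the core of compound 3 differs from the core of compound 1 is not broken down here.

Compound 4 `Cn1ccc2c(Oc3ccc(NC(=O)c4nn(-c5ccc(Cl)cc5)ccc4=O)cc3F)ccnc21` is not yet measured. It differs from compound 3 by fluoro in place of hydrogen on an aromatic carbon, the same change as from compound 1 to compound 2, at a place described in the same words. Since that change gave a modestly higher number in the one measured case, and compound 3 already stands at a limit, compound 4 is expected to stay at or beyond that limit, a step that the limit leaves unreadable from compound 3 to compound 4. Compound 4 is therefore estimated at 100000 nM, between 50000 nM and 300000 nM, most likely reported as a limit.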

Compound 4, half-maximal inhibitory concentration: > 60000 nM
Compound 4 ended at the assay's limit; the forecaster's own chance of this, stated with the estimate: 80%; the middle value does not contradict the limit.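

In this assay compound 4 gives > 60000 nM, which is a limit and not a number. Compound 3 also stands at a limit, so the step between compound 3 and compound 4 cannot be read: the limit of > 60000 nM in this assay, at which 2 of the 4 values shown sit.

The compounds shown leave open whether fluoro in place of hydrogen changes the number on the core of compound 3 as it did on the core of compound 1.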